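A few compounds are considered here, and "the series" means these few. Any claim that something is new, unique, unknown or untested is made for them only; others in the source may bear on it.

Working notes. In an ADME assay on CHO cells (Cricetulus griseus) for cytotoxicity, read by MTT assay, with a stated time of 24 h (a lower number here means that less compound is tolerated, a higher number that more compound is tolerated), compound 1 `CC1Cn2cc([N+](=O)[O-])nc2O1` gives > 500000 nM, which is a limit. Compound 2 `CC1Cn2c(nc([N+](=O)[O-])c2-c2ccc(Cl)cc2)O1` gives > 250000 nM, also a limit. Compound 3 `Cc1ccc(-c2c([N+](=O)[O-])nc3n2CC(C)O3)s1` gives > 125000 nM, again a limit. Compound 2 therefore has no exact value, and neither do the other two compounds. Compound 4 `CCCOc1ccc(-c2c([N+](=O)[O-])nc3n2CC(C)O3)cc1` differs from compound 2 as follows: propoxy in place of chloro on an aromatic carbon. Among the measured compounds shown here, the only measured step, a step that the two limits leave unreadable from compound 1 to compound 3, has no readable size, so it gives no direction for this change. No step beyond the scatter is therefore expected in this assay. The expected step is an at least 1.2-fold lower number from compound 2 to compound 4 (0.09 log units; that floor lies within the scatter). Compound 4 is estimated at 200000 nM, with an expected range of 80000 nM to 500000 nM.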

Compound 4, half-maximal cytotoxic concentration: > 125000 nM
Compound 4 was reported as a limit; the forecaster's own chance of this, stated with the estimate: 75%; the middle value does not contradict the limit.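

Compound 2 and compound 4 both stand as limits in this assay, and the step between them cannot be read. The compounds shown leave open whether propoxy in place of chloro on an aromatic carbon changes the tolerated concentration at all.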